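Fluoro on the benzyl ring: compound 3 to compound 4

The source may hold more compounds than are shown below. What is called first, only, known or untested is meant among the compounds shown, and "the series" means these compounds.

Of the compounds shown here, three share one core and have been tested in a functional assay on the whole organism (artery, strain albino) with Rattus norvegicus as the target, with a stated time of 30 min, at a dose of 10 mg/kg by the oral route; on this read-out lower numbers stand for less inhibition and higher numbers for more inhibition at the one dose given (going by the name of the read-out). Compound 1 `CC1=C(C(=O)Nc2ccc(Br)cc2)C(c2ccc(Cl)cc2Cl)N=C(SCc2ccccc2)N1` gives 3.6%. Compound 2 `CC1=C(C(=O)Nc2ccc(Br)cc2)C(c2ccc(Cl)cc2Cl)N=C(SCc2ccc(Cl)cc2)N1` gives 6.7%, and compound 3 `COc1ccc(C2N=C(SCc3ccccc3)NC(C)=C2C(=O)Nc2ccc(Br)cc2)cc1` gives 2.6%. On these numbers compound 3 gives the smallest reading, yet its gap to compound 1 and to compound 2 both lie within the scatter, so the three compounds cannot be told apart on this read-out.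

The next compound, compound 4 `COc1ccc(C2N=C(SCc3ccc(F)cc3)NC(C)=C2C(=O)Nc2ccc(Br)cc2)cc1`, differs from compound 3 in one place: fluoro in place of hydrogen on an aromatic carbon. The new fluorine sits para to a large group on the benzylsulfanyl part.

For the measured compounds named here, one measured step bears on this. It is a number 3.1 percentage points higher from compound 1 to compound 2 (within the scatter), where a chloro entered the same kind of position on the same ring. That step stayed within the scatter. A fluoro is a smaller halogen entering the same place, and nothing among the three compounds shows a substituent there moving this read-out beyond the scatter. The other measured step, a number 1 percentage points lower from compound 1 to compound 3 (within the scatter), concerns a different ring and also stayed within the scatter.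

For compound 4 the expected step is therefore a number 1.9 percentage points higher from compound 3 to compound 4 (within the scatter), a change not expected to exceed the scatter. The estimate for compound 4 is 4.5%, with a range from 0% to 12%.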

Compound 4, a percentage reported as inhibition, in the whole organism at one dose (the size of the read-out at that dose, not a potency): 6.2%
Compound 4: the middle estimate sits 1.7 percentage points below what was measured; the range from low to high includes it.
By their numbers in this assay, from the lowest: compounds 3, 1, 4 and 2 (each within the scatter of the next).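

Fluoro on the benzyl ring gives a step in this assay that stays within the scatter: a number 3.6 percentage points higher from compound 3 to compound 4 (within the scatter). The earlier chloro step, a number 3.1 percentage points higher from compound 1 to compound 2 (within the scatter), also stayed within the scatter, but it was read with a 2,4-dichlorophenyl group on the saturated ring carbon, whereas this one is read with a 4-methoxyphenyl group there. So two different halogens, each para to a large group and each read with a different group on that ring carbon, now give steps that cannot be told from repeat-measurement noise, and nothing available explains the size of the new step.

As far as these compounds go, what remains open is whether any group at this place can move the reading beyond the scatter, for instance an amine or a carboxylic acid on the benzyl ring in place of the halogen. The compounds shown also leave open whether fluoro in this place would give a similar step when the saturated ring carbon carries the 2,4-dichlorophenyl group of compound 1.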